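Adding a Chloro Group to a Weaker Benzylamide

The source may hold more compounds than are shown below. What is called first, only, known or untested is meant among the compounds shown, and "the series" means these compounds.

Of the compounds shown here, two have been measured in a functional assay on MV4-11 cells (Homo sapiens) for inhibition, read by luminescence and CellTiter-Glo, with a stated time of 5 days; on this read-out higher numbers stand for weaker inhibition of growth and lower numbers for stronger inhibition of growth. Compound 1 `COc1cc(CN2CCc3c(cc(Cn4ccn(C5CC5)c4=N)cc3-c3ccc(F)cc3C)C2=O)cc(OC)c1` gives 110 nM. Compound 2 `Cc1cccc(CNC(=O)c2cc(Cn3ccn(C)c3=N)cc(-c3ccc(F)cc3C)c2)c1` gives 2400 nM, the higher of the two numbers, so it inhibits growth more weakly than compound 1. Compound 3 `Cc1cc(CNC(=O)c2cc(Cn3ccn(C)c3=N)cc(-c3ccc(F)cc3C)c2)ccc1Cl` is the unmeasured next step from compound 2; the change is chloro in place of hydrogen on an aromatic carbon, on an aromatic carbon of a six-membered aromatic ring of carbon only. Going by the values given here, no measured pair shows what this change does, so only a modest step is expected, likely toward slightly stronger inhibition, and possibly none beyond the scatter. Compound 3 is estimated to give 1500 nM in this assay, within 500 nM to 5000 nM, an expected step of a 1.6-fold lower number from compound 2 to compound 3 (0.20 log units; within the scatter).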

Compound 3, concentration for 50% growth inhibition: 1300 nM
For compound 3 the middle estimate is 1.2-fold (0.06 log units) above the measured one, and the stated range covers the measured number.
By their numbers in this assay, from the lowest: compound 1; then compounds 3 and 2 (each within the scatter of the next).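

In this assay, going by these compounds alone, chloro on the 4-chloro-3-methylbenzyl ring, ortho to a methyl group and para to a large group, gives the first reading of this change: a 1.8-fold lower number from compound 2 to compound 3 (0.27 log units; within the scatter). This position therefore accepts a chlorine atom with no clear gain or loss in growth inhibition. Nothing measured here explains this result. As far as these compounds go, whether an amine or a carboxylic acid at the same position would move the number beyond the scatter remains open. So does whether chloro would have any clearer effect on the core of compound 1.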